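The source may hold more compounds than are shown below. What is called first, only, known or untested is meant among the compounds shown, and "the series" means these compounds.

Working notes on a small fluorinated series screened in a toxicity assay on the whole organism (strain CD-1) for cytotoxicity, with Mus musculus as the target, with a stated time of 14 days, at a dose of 300 mg/kg by the intraperitoneal route; on this read-out lower numbers stand for a stronger effect and higher numbers for a weaker effect at the one dose given. Compound 1, `COc1c(C(=O)O)cc(F)c(F)c1F`, gives 0% in this assay. Compound 2, `CC(=O)Oc1c(F)c(F)c(F)c(F)c1C(=O)O`, gives 0% in this assay, so compound 2 stands level with compound 1 at the digits reported, and the two readings lie within the scatter of each other. Neither reading is a limit of the assay. Within the data shown here, no step between measured compounds that differ in one place is available, so the series so far offers no measured structure-activity relationship to lean on.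

Compound 3, `CC(=O)Oc1c(C(=O)O)cc(F)c(F)c1F`, is not yet measured in this assay. Relative to compound 2 the change is hydrogen in place of fluoro on an aromatic carbon. The two measured compounds return the same reading in this assay, and nothing in that pair points to a change of this kind shifting the read-out, so the expected step in this assay is no change at the digits printed from compound 2 to compound 3 (within the scatter), none beyond the scatter. Compound 3 is accordingly expected to give 0% in this assay, within a range from 0% to 10%. The measured reading is awaited.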

Compound 3, a percentage reported as activity, at one dose (the size of the read-out at that dose, not a potency): 0%
Compound 3: middle estimate and measured number agree at the digits printed; the range from low to high includes it.
By their numbers in this assay, from the lowest: compounds 1, 2 and 3 (each within the scatter of the next).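

In this assay the series now has its first steps between compounds that differ in one place, and each change can be read alone. Hydrogen in place of fluoro on the aromatic carbon ortho to a carboxy group reads as no change at the digits printed from compound 2 to compound 3 (within the scatter), and acetyl in place of methyl on an oxygen on an aromatic ring reads as no change at the digits printed from compound 1 to compound 3 (within the scatter), so at this one dose neither this fluoro position nor the choice between these two groups on the oxygen separates the compounds. No measurement shown here bears on why these readings coincide.

The compounds shown leave open whether a group other than fluoro or hydrogen on this aromatic carbon, such as an amine or a nitrile, would read the same, and whether a longer chain on the oxygen, such as butanoyl, would do so. They also leave open what an amide in place of the carboxy group would give in this assay.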